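Bromo, trifluoromethyl and nitro on one pyridyl urea scaffold

This account rests on a few compounds, and the source may have more. Where it says the series, first, only, none or still open, it means among the compounds named here.

In a functional assay on the whole organism with Mus musculus as the target, in the maximal electroshock model, with a stated time of 30 min (a lower number here means that less compound is needed, a higher number that more compound is needed for the effect), compound 1 `O=C(Nc1ccncc1)Nc1ccccc1Br` gives 100 mg/kg. Compound 2 `O=C(Nc1ccncc1)Nc1ccccc1C(F)(F)F` differs from it by a trifluoromethyl in place of bromo on an aromatic carbon, and in this assay compound 2 gives 100 mg/kg; the step of no change at the digits printed from compound 1 to compound 2 (within the scatter) lies within the scatter, so compound 2 stands level with compound 1 and no ordering between the two can be drawn. Compound 3 `O=C(Nc1ccncc1)Nc1ccccc1[N+](=O)[O-]` is not yet measured. It differs from compound 2 by nitro in place of trifluoromethyl on an aromatic carbon. Among the measured compounds shown here, the only step that bears on this change is no change at the digits printed from compound 1 to compound 2 (within the scatter), which showed that exchanging one group for another at this position left the minimum effective dose unchanged. On that single precedent no step beyond the scatter is expected from compound 2 to compound 3, so the estimated step is no change at the digits printed from compound 2 to compound 3 (within the scatter). Compound 3 is therefore expected to give about 100 mg/kg, with a range from 40 mg/kg to 250 mg/kg.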

Compound 3, minimum effective dose: 300 mg/kg
Beside the measured number, compound 3's estimate is 3.0-fold (0.48 log units) below it; the whole stated range lies below it.
By their numbers in this assay, from the lowest: compounds 1 and 2 (each within the scatter of the next); then compound 3.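

In this assay, this position turns out to respond to a change of group: nitro in place of trifluoromethyl gives a 3.0-fold higher number from compound 2 to compound 3 (0.48 log units; beyond the scatter) and nitro in place of bromo gives a 3.0-fold higher number from compound 1 to compound 3 (0.48 log units; beyond the scatter) in the same direction. The earlier exchange of bromo for trifluoromethyl alone gave no sign of this, so among these three compounds, only the exchanges that bring in nitro move the minimum effective dose, and more compound is then needed for the effect. Nothing available bears on why nitro departs from the other two groups.

The compounds shown leave open whether an amine, a carboxylic acid or a methoxy group at this place would stay level with bromo and trifluoromethyl or move with nitro. They also leave open whether nitro would give the same step on another aromatic carbon of this ring.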